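Swapping Methoxy for Phenyl on a Shared Amide Tail

The source may report more compounds than this note shows. Statements on the series, on what has been measured and on what is new or still open speak of the compounds shown alone.

Compound 1 `COc1ccc(NC(=O)COc2c(-c3ccccc3)oc3ccccc3c2=O)cc1` and compound 2 `O=C(COc1c(-c2ccccc2)oc2ccccc2c1=O)Nc1ccc(-c2ccccc2)cc1` share one core and differ in a single place: phenyl in place of methoxy on an aromatic carbon. In a functional assay on NPC-TW01 cells (Homo sapiens) for antiproliferative activity, read by MTT assay, with a stated time of 72 h (a lower number here means a stronger inhibitor of growth, a higher number a weaker inhibitor of growth), compound 1 gives 5480 nM. For compound 2 this assay reports only a limit, > 10000 nM. The step of an at least 1.8-fold higher number from compound 1 to compound 2 (0.26 log units; that floor lies within the scatter) therefore rests on that limit, (the limit of > 10000 nM in this assay, at which 1 of the 3 values shown sits), so its true size is not known, only its floor.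

Compound 3 `COc1ccc(NC(=O)COc2ccc3c(=O)cc(-c4ccccc4)oc3c2)cc1` is built from the same atoms as compound 1, joined differently; the difference between the two cores is not broken down here. In this assay compound 3 gives 5970 nM, a value that sits within the scatter of compound 1.

Compound 4 `O=C(COc1ccc2c(=O)cc(-c3ccccc3)oc2c1)Nc1ccc(-c2ccccc2)cc1` has not yet been measured. It stands to compound 3 exactly as compound 2 stands to compound 1: phenyl in place of methoxy on an aromatic carbon. The change is the same as before, at the same kind of place.

Compound 4 is expected to weaken growth inhibition by about a 2.5-fold higher number from compound 3 to compound 4 (0.40 log units; beyond the scatter) because the same change produced an at least 1.8-fold higher number from compound 1 to compound 2 (0.26 log units; that floor lies within the scatter). Compound 4 is therefore estimated at 15000 nM, with a likely range from 6000 nM to 40000 nM, and a real chance that this assay again reports only a limit.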

Compound 4, concentration for 50% growth inhibition: 1610 nM
Estimate against measurement, compound 4: 9.3-fold (0.97 log units) above, and the stated range ends above it.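

In this assay, phenyl in place of methoxy gives a 3.7-fold lower number from compound 3 to compound 4 (0.57 log units; beyond the scatter), a stronger inhibitor of growth, whereas the same change on the core of compound 1 brings no such gain, and the two steps clearly differ: the same change on two cores in this assay, an at least 1.8-fold higher number (0.26 log units; that floor lies within the scatter) from compound 1 to compound 2 and a 3.7-fold lower number (0.57 log units; beyond the scatter) from compound 3 to compound 4, at least 6.7-fold (0.83 log units) apart, beyond the scatter of two such steps. So on these two cores, the result of this change on one did not carry over to the other, although two pairs of compounds cannot explain why the cores part ways or predict what a third core would do. As far as these compounds go, compound 2 is known only through a limit, > 10000 nM, so the true size of its step remains unknown.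

The compounds shown leave open whether a different group at the same place on the amide tail, such as an amine, a carboxylic acid or a longer chain, would also behave differently on the two cores. They also leave open whether the gain seen with phenyl on the core of compound 3 would hold for a second ring of another kind.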